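The source may report more compounds than this note shows. Statements on the series, on what has been measured and on what is new or still open speak of the compounds shown alone.

Notes on the series. Compound 1 `CN(c1ccn(C)n1)c1cnc(NCc2c(F)ccc3c2CCO3)c2cn[nH]c(=O)c12` gives 2.4 in a physicochemical assay for lipophilicity, using the shake flask method, in phosphate buffer, measured as octanol-water partition, with a stated time of 30 min, at pH 7.4; on this read-out lower numbers stand for lower lipophilicity and higher numbers for higher lipophilicity. Compound 2 `CN(C)C(=O)c1cc(-c2cnc(NCc3c(F)ccc4c3CCO4)c3cn[nH]c(=O)c23)n(C)n1` gives 2.1 in this assay, and compound 3 `O=C1CCCN1c1cnc(NCc2c(F)ccc3c2CCO3)c2cn[nH]c(=O)c12` gives 1.8. Compound 3 stands lowest of the three numbers: nearest is compound 2, with a number 0.30 log units lower from compound 2 to compound 3 (within the scatter); furthest is compound 1, with a number 0.60 log units lower from compound 1 to compound 3 (beyond the scatter). Compound 4 `CC(=O)N1CCC(c2cnc(NCc3c(F)ccc4c3CCO4)c3cn[nH]c(=O)c23)CC1` is not yet measured; it differs from compound 3 by 1-acetylpiperidin-4-yl in place of 2-oxopyrrolidin-1-yl on an aromatic carbon. For the measured compounds named here, no measured step exchanges this group, so only the two steps into compound 3 bear on it, and both are small. The step of a number 0.20 log units higher from compound 3 to compound 4 (within the scatter) is therefore expected to be none beyond the scatter. For compound 4 the estimate in this assay is 2, expected to fall between 1.6 and 2.4.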

Compound 4, distribution coefficient: 2.9
Compound 4: middle estimate off by 0.90 log units, on the low side, and the stated range ends below it.
By their numbers in this assay, from the lowest: compounds 3, 2 and 1 (each within the scatter of the next, the first and the last beyond it); then compound 4.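

In this assay the exchange at this position gives a number 1.10 log units higher from compound 3 to compound 4 (beyond the scatter) even though 1-acetylpiperidin-4-yl and 2-oxopyrrolidin-1-yl each hold one non-aromatic ring and one hydrogen-bond acceptor, so matching those counts does not keep the number in place. The same group also stands beyond the scatter from the other two groups, with a number 0.80 log units higher from compound 2 to compound 4 (beyond the scatter) and a number 0.50 log units higher from compound 1 to compound 4 (beyond the scatter) as the steps. No measured evidence accounts for these steps.

Open, going by these compounds, is whether the acetyl group or the six-membered ring carries the step. Also open, on these data alone, is where a free amine or a carboxylic acid on that ring would fall.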